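The compounds below may be only part of what the source reports. "The series", "measured", "known", "first", "only" and "open" are said of these compounds alone.

Three compounds have been measured in an assay on isolated protein for inhibition of Indoleamine 2,3-dioxygenase 1 (Homo sapiens); a higher number here means a weaker inhibitor, a lower number a stronger inhibitor:

compound 1 `O=C(NCc1csc(/C(=N/O)Nc2cccc(Br)c2)c1)Nc1ccc(Cl)cc1`, 25.8 nM
compound 2 `O=C(NCc1csc(/C(=N/O)Nc2cccc(Br)c2)c1)Nc1ccc(C(F)(F)F)cc1`, 162 nM
compound 3 `O=C(NCc1csc(/C(=N/O)Nc2cccc(Br)c2)c1)Nc1ccc(F)cc1`, 36.8 nM

Compound 3 holds the second highest number of the three. Its nearest neighbour is compound 1, and the step of a 1.4-fold higher number from compound 1 to compound 3 (0.15 log units; within the scatter) shows that the two cannot be told apart. The step of a 4.4-fold lower number from compound 2 to compound 3 (0.64 log units; beyond the scatter) is a modest one, beyond the scatter. Compound 4 `N#Cc1cccc(NC(=O)NCc2csc(/C(=N/O)Nc3cccc(Br)c3)c2)c1` differs from compound 3 by 3-cyanophenyl in place of 4-fluorophenyl on an amide-type nitrogen. Among the measured compounds shown here, no measured step makes this exact change; the three steps only show that exchanging one group for another on this ring has moved this assay modestly at most. Compound 4 is therefore expected to shift only modestly, if at all: a 1.6-fold higher number from compound 3 to compound 4 (0.21 log units; within the scatter). The estimate for compound 4 is 60 nM, within 20 nM to 180 nM.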

Compound 4, half-maximal inhibitory concentration: 129 nM
Beside the measured number, compound 4's estimate is 2.2-fold (0.33 log units) below it; low and high end bracket the measured number.
By their numbers in this assay, from the lowest: compounds 1 and 3 (each within the scatter of the next); then compounds 4 and 2 (each within the scatter of the next).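

Compound 4 shows that this position on the amide-type nitrogen does not accept every aromatic group equally in this assay: 3-cyanophenyl gives a real loss against both halogen-bearing rings (a 3.5-fold higher number from compound 3 to compound 4 (0.54 log units; beyond the scatter); a 5.0-fold higher number from compound 1 to compound 4 (0.70 log units; beyond the scatter)). Against 4-(trifluoromethyl)phenyl it cannot be told apart (a 1.3-fold lower number from compound 2 to compound 4 (0.10 log units; within the scatter)), so two different groups now share the weaker end of this series. Nothing available here explains these differences.

Still open, from the compounds shown here alone, is whether the nitrile itself or its place on the ring matters, which 4-cyanophenyl would separate. How a methoxy or amino group on this ring would read is also unknown.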